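Working notes on the 2-hydroxyphenyl series

This account rests on a few compounds, and the source may have more. Where it says the series, first, only, none or still open, it means among the compounds named here.

Of the compounds shown here, three built on the shared core have been measured in an assay on CHO cells for displacement of a labelled ligand from adenosine receptor A3 (Homo sapiens), read by scintillation counting, with a stated time of 60 min, tested at 1 uM; on this read-out higher numbers stand for more inhibition at the one concentration tested (going by the name of the read-out) and lower numbers for less inhibition. Compound 1 `Nc1nc(Cc2ccccc2)nc2cn(-c3ccccc3O)nc12` gives 19% and stands second highest of the three numbers. Compound 2 `Nc1nc(-c2ccco2)nc2cn(-c3ccccc3O)nc12` gives 36%, and compound 3 `Nc1nc(CCCc2ccccc2)nc2cn(-c3ccccc3O)nc12` gives 5%. Both measured steps alter the group on the aromatic carbon of the core: a number 17 percentage points higher from compound 1 to compound 2 (beyond the scatter) with furan-2-yl in place of benzyl, and a number 14 percentage points lower from compound 1 to compound 3 (beyond the scatter) with phenethyl in place of phenyl on a saturated chain carbon bound to an aromatic carbon. Each lies beyond the scatter, yet neither changes anything at the aromatic nitrogen.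

Compound 4 `Cn1cc2nc(Cc3ccccc3)nc(N)c2n1` differs from compound 1 in one place: methyl in place of 2-hydroxyphenyl on an aromatic nitrogen. Within the data shown here, no measured step bears on this position, so the two steps from compound 1 only show the size of change this core has given elsewhere, not a direction for the aromatic nitrogen. With the benzyl kept and the 2-hydroxyphenyl gone, the number expected for compound 4 in this assay is estimated at 10%, within 0% to 28%. The expected step of a number 9 percentage points lower from compound 1 to compound 4 (within the scatter) is estimated to lie near the edge of the scatter, more likely downward than upward.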

Compound 4, a percentage reported as inhibition, at one concentration (the size of the read-out at that concentration, not a potency): 1%
Estimate against measurement, compound 4: 9 percentage points above; the measured number falls inside the stated range.
By their numbers in this assay, from the lowest: compounds 4 and 3 (each within the scatter of the next); then compound 1; then compound 2.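

In this assay, the aromatic nitrogen now has a measured step of its own: methyl in place of 2-hydroxyphenyl gives a number 18 percentage points lower from compound 1 to compound 4 (beyond the scatter), so the group on this nitrogen matters to the read-out, although the step is modest, the same grade as the two printed for changes at the aromatic carbon. Among these compounds, with the benzyl kept, this one change takes away the six-membered aromatic ring, the hydrogen-bond donor and the hydrogen-bond acceptor together, and the single step cannot assign the drop to any one of them. Nothing at hand gives a cause for this step.

As far as these compounds go, it remains open whether the number depends on the aromatic ring itself or on its hydroxyl, a question that phenyl or 2-methoxyphenyl on the aromatic nitrogen would bear on, and whether a longer chain such as propyl would read differently from methyl. From the compounds shown here alone, it also remains open whether the same change at the aromatic nitrogen would give a step of similar size with furan-2-yl in place of benzyl on the aromatic carbon.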